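Chloro for hydrogen on the aryl ring of compound 2

A few compounds are considered here, and "the series" means these few. Any claim that something is new, unique, unknown or untested is made for them only; others in the source may bear on it.

In an assay on isolated protein for inhibition of leukotriene A-4 hydrolase (Homo sapiens) (a lower number here means a stronger inhibitor, a higher number a weaker inhibitor), compound 2 `N=c1scc(-c2ccccc2)n1CC(=O)N1CCOCC1` gives 8650 nM, the highest of the three numbers in hand; compound 1 `Cc1ccc(-c2csc(=N)n2CC(=O)N2CCN(c3ccccc3)CC2)cc1` gives 4290 nM, within the scatter of compound 2, and compound 3 `CN1CCN(C(=O)Cn2c(-c3ccccc3)csc2=N)CC1` gives 629 nM. For the measured compounds named here, the one measured step, a 14-fold lower number from compound 2 to compound 3 (1.14 log units; beyond the scatter), sits on the carbonyl carbon and tells nothing about the aryl ring. Compound 4 `N=c1scc(-c2ccc(Cl)cc2)n1CC(=O)N1CCOCC1` differs from compound 2 thus: chloro in place of hydrogen on an aromatic carbon. Going by the values given here, no measured step bears on this change; compound 1 differs from compound 2 in two places at once, so its value settles nothing here. For compound 4 no step beyond the scatter in this assay is expected, a 1.3-fold lower number from compound 2 to compound 4 (0.12 log units; within the scatter). The estimate for compound 4 is 6500 nM, with a range from 2000 nM to 20000 nM.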

Compound 4, inhibition constant: 1060 nM
For compound 4 the middle estimate is 6.1-fold (0.79 log units) above the measured one; the measured number lies below the stated range.
By their numbers in this assay, from the lowest: compounds 3 and 4 (each within the scatter of the next); then compounds 1 and 2 (each within the scatter of the next).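

In this assay the aryl ring now has a measured step of its own: an 8.2-fold lower number from compound 2 to compound 4 (0.91 log units; beyond the scatter) for chloro in place of hydrogen, para to a large group. This puts the aromatic carbon alongside the carbonyl carbon, where a 14-fold lower number from compound 2 to compound 3 (1.14 log units; beyond the scatter) was already seen, as a second place in compound 2 where one change moves the number beyond the scatter. Nothing measured bears on the origin of this step.

Still open, going by these compounds, is whether fluoro, methoxy or an amine at the same place gives a similar step. Also open, on these data alone, is whether chloro there adds to the 4-methylpiperazin-1-yl change of compound 3.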